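The source may report more compounds than this note shows. Statements on the series, on what has been measured and on what is new or still open speak of the compounds shown alone.

Measured so far:
- Compound 1, `CNC(=O)c1cccc(Cn2nc(C)c(NC(=O)c3ccc(COc4ccccc4C)cc3)c2C)c1`: 2100 nM
- Compound 2, `CNC(=O)c1cccc(Cn2nc(C)c(NC(=O)c3ccc(COc4ccc(C)cc4)cc3)c2C)c1`: 2600 nM
- Compound 3, `CNC(=O)c1cccc(Cn2nc(C)c(NC(=O)c3ccc(COc4cccc(OC)c4)cc3)c2C)c1`: 6200 nM

These three values come from a functional assay on MIA PaCa-2 cells (Homo sapiens) for antiproliferative activity, read by MTT assay, with a stated time of 72 h; a lower number here means that less compound is needed, a higher number that more compound is needed for the effect. Compound 3 stands highest of the three: its nearest neighbour is compound 2, with a step of a 2.4-fold higher number from compound 2 to compound 3 (0.38 log units; beyond the scatter), and the furthest is compound 1, with a step of a 3.0-fold higher number from compound 1 to compound 3 (0.47 log units; beyond the scatter). Compound 1 and compound 2 differ from each other only by a 1.2-fold higher number from compound 1 to compound 2 (0.09 log units; within the scatter), a difference within the scatter.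

Compound 4, `CNC(=O)c1cccc(Cn2nc(C)c(NC(=O)c3ccc(COc4ccc(Cl)cc4)cc3)c2C)c1`, has not yet been measured. It differs from compound 3 in one place: 4-chlorophenyl in place of 3-methoxyphenyl on an oxygen on a saturated carbon. The two steps that bear on this change are the ones leading into compound 3 from compound 1 and compound 2, which both show that 3-methoxyphenyl gave a modestly higher number than 2-methylphenyl or 4-methylphenyl. The 4-chlorophenyl group of compound 4 is a substituted phenyl without the methoxy acceptor, as are those of compound 1 and compound 2, so the change is expected to undo most of that modest rise. Compound 4 is therefore estimated at 2600 nM, with a range from 1200 nM to 5500 nM. This expectation means a step of a 2.4-fold lower number from compound 3 to compound 4 (0.38 log units; beyond the scatter).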

Compound 4, half-maximal effective concentration: 4200 nM
Beside the measured number, compound 4's estimate is 1.6-fold (0.21 log units) below it; low and high end bracket the measured number.
By their numbers in this assay, from the lowest: compounds 1, 2, 4 and 3 (each within the scatter of the next, the first and the last beyond it).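

In this assay, 4-chlorophenyl in place of 3-methoxyphenyl on this oxygen gives a 1.5-fold lower number from compound 3 to compound 4 (0.17 log units; within the scatter), so removing the methoxy group does not clearly return the number to the range of the methyl compounds. Compound 4 also cannot be separated from either methyl compound: chloro in place of methyl gives a 1.6-fold higher number from compound 2 to compound 4 (0.21 log units; within the scatter), and the change from 2-methylphenyl to 4-chlorophenyl gives a 2.0-fold higher number from compound 1 to compound 4 (0.30 log units; within the scatter), so compound 4 overlaps with all three earlier compounds, even though compound 3 stands clear of compound 1 and compound 2. No measurement here accounts for these small differences.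

All four compounds carry a phenyl ring with one small substituent on this oxygen. On these data alone, whether an amine or a carboxylic acid on that ring would shift the number beyond the scatter remains open.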